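Replacing the methyl-oxazole of compound 1 with cyclopentyl

The compounds below may be only part of what the source reports. "The series", "measured", "known", "first", "only" and "open" are said of these compounds alone.

Measured so far in an ADME assay on microsomes from liver (Rattus norvegicus) for metabolic stability, with a stated time of 60 min, tested at 1 uM; on this read-out lower numbers stand for a less stable compound and higher numbers for a more stable compound:
- compound 1 `COc1cc(-c2cnn3cc(OC)c(-c4cc(C)no4)nc23)ccn1`: 62%
- compound 2 `Cn1cc(-c2nc3c(-c4ccnc(OC5CC5)c4)cnn3cc2OCC(C)(C)O)cn1`: 81%

Compound 1 gives the lower of the two numbers at 62%, and compound 2 gives 81%, a gap that lies beyond the usual scatter. These two compounds differ in more than one place, so that gap assigns nothing to any single group. Still unmeasured is compound 3 `COc1cc(-c2cnn3cc(OC)c(C4CCCC4)nc23)ccn1`, which carries this change: cyclopentyl in place of 3-methyl-1,2-oxazol-5-yl on an aromatic carbon. Cyclopentyl replaces 3-methyl-1,2-oxazol-5-yl on an aromatic carbon, ortho to a methoxy group. Going by the values given here, no measured pair isolates this change, so the expectation rests on the structure alone and carries a wide range. A moderate fall in this assay is expected, probably beyond the scatter. The estimated change is a number 17 percentage points lower from compound 1 to compound 3 (beyond the scatter). For compound 3 the expected value is 45%, with an estimated range of 20% to 70%.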

Compound 3, percent of the compound remaining: 7%
Compound 3: the middle estimate sits 38 percentage points above what was measured, and the stated range ends above it.
By their numbers in this assay, from the lowest: compound 3; then compound 1; then compound 2.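

In this assay, going by these compounds alone, the exchange of 3-methyl-1,2-oxazol-5-yl for cyclopentyl on this aromatic carbon, ortho to a methoxy group, gives a number 55 percentage points lower from compound 1 to compound 3 (beyond the scatter) and so provides the first reading of a single change. With all else in the core of compound 1 held constant, the group at this position has a large bearing on the percent of compound remaining. No measurement at hand accounts for the size of this step.

The compounds shown leave open whether the step follows the loss of the aromatic ring or the loss of the ring hetero atoms, a question that phenyl and tetrahydrofuranyl at this position would help to separate. They also leave open how an amine or a longer alkyl chain would read here.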